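The source may hold more compounds than are shown below. What is called first, only, known or untested is meant among the compounds shown, and "the series" means these compounds.

In a functional assay on SW-620 cells (Homo sapiens) for cytotoxicity, read by MTT assay, with a stated time of 48 h (on this read-out lower numbers stand for stronger inhibition and higher numbers for weaker inhibition), compound 1 `CCCCCCCCNC(=O)[C@@H](NC(=O)c1cccs1)[C@@H](C)O` gives 136000 nM, compound 2 `CCCCCCCCCCCCNC(=O)[C@@H](NC(=O)c1cccs1)[C@@H](C)O` gives 29200 nM, and compound 3 `CCCCCCCCCCCCCCNC(=O)[C@@H](NC(=O)c1cccs1)[C@@H](C)O` gives 78400 nM.

Compound 3 stands second highest of these three numbers: its nearest neighbour is compound 1, whose value sits within the scatter of it, while compound 2 lies further off, with a 2.7-fold higher number from compound 2 to compound 3 (0.43 log units; beyond the scatter). Compound 4 `C/C=C/C=C/C(=O)N[C@H](C(=O)NCCCCCCCCCCCCCC)[C@@H](C)O` alters the acyl end instead of the chain: penta-1,3-dien-1-yl in place of thiophen-2-yl on a carbonyl carbon. The measured steps, a 4.7-fold lower number from compound 1 to compound 2 (0.67 log units; beyond the scatter) and a 1.7-fold lower number from compound 1 to compound 3 (0.24 log units; within the scatter), concern only the chain length, so none of them bears on this change, and there is no basis for expecting a shift beyond the scatter in this assay. Compound 4 is therefore expected to give 70000 nM, within a range from 20000 nM to 250000 nM. That expectation amounts to a step of a 1.1-fold lower number from compound 3 to compound 4 (0.05 log units; within the scatter).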

Compound 4, half-maximal inhibitory concentration: 200000 nM
The estimate for compound 4 lay 2.9-fold (0.46 log units) below the measured number; low and high end bracket the measured number.
By their numbers in this assay, from the lowest: compound 2; then compounds 3, 1 and 4 (each within the scatter of the next, the first and the last beyond it).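

The acyl end matters in this assay: penta-1,3-dien-1-yl in place of thiophen-2-yl on a carbonyl carbon gives a 2.6-fold higher number from compound 3 to compound 4 (0.41 log units; beyond the scatter) and so weakens inhibition modestly. Within the data shown here, the earlier steps changed only the chain, so this is the first sign that this position also moves the number. Nothing available explains why this change has this effect.

From the compounds shown here alone, whether the ring itself or its sulfur counts remains open, and phenyl or furan-2-yl at this carbonyl would help separate the two. Also open, going by these compounds, is whether the same change on the shorter chain of compound 2 gives a similar step.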